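The source may hold more compounds than are shown below. What is called first, only, known or untested is meant among the compounds shown, and "the series" means these compounds.

Measured in an ADME assay on HeLa cells (Homo sapiens) for cytotoxicity, with a stated time of 72 h; on this read-out lower numbers stand for higher toxicity in this test and higher numbers for lower toxicity in this test:

Compound 1 `CC(C)C[C@H](N)C(=O)Nc1ccc(NC(=O)/C=C/c2ccc(-c3ccc([N+](=O)[O-])cc3)o2)cc1C(=O)c1ccccc1`: > 83000 nM (a limit)
Compound 2 `CC[C@H](C)[C@H](N)C(=O)Nc1ccc(NC(=O)/C=C/c2ccc(-c3ccc([N+](=O)[O-])cc3)o2)cc1C(=O)c1ccccc1`: > 83000 nM (a limit)
Compound 3 `CSCC[C@H](N)C(=O)Nc1ccc(NC(=O)/C=C/c2ccc(-c3ccc([N+](=O)[O-])cc3)o2)cc1C(=O)c1ccccc1`: > 81000 nM (a limit)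

Compound 1 stands at the limit of > 83000 nM in this assay, at which 2 of the 3 values shown sit, so it offers a limit and no number. Compound 4 `CSCC[C@@H](N)C(=O)Nc1ccc(NC(=O)/C=C/c2ccc(-c3ccc([N+](=O)[O-])cc3)o2)cc1C(=O)c1ccccc1` keeps the core of compound 1 and differs on a carbonyl carbon, where 1-amino-3-(methylsulfanyl)propyl takes the place of 1-amino-3-methylbutyl: 1-amino-3-(methylsulfanyl)propyl in place of 1-amino-3-methylbutyl on a carbonyl carbon. The closest evidence is a step that the two limits leave unreadable from compound 1 to compound 3. Compound 3, which carries the same 1-amino-3-(methylsulfanyl)propyl group, gives > 81000 nM, again a limit. The other two changes, a step that the two limits leave unreadable from compound 1 to compound 2 and a step that the two limits leave unreadable from compound 2 to compound 3, give no readable size either. No step beyond the usual scatter is therefore expected in this assay, and another limit is the likeliest report. The expected change is an at least 1.0-fold lower number from compound 1 to compound 4 (0.01 log units; that floor lies within the scatter). For compound 4 the estimate is 81000 nM, with an expected range from 30000 nM to 110000 nM.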

Compound 4, half-maximal cytotoxic concentration: > 81000 nM
Compound 4 gave a limit, no number (the forecaster's own chance of this, stated with the estimate: 85%); the middle value lies on the limit itself.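

In this assay, within the data shown here, compound 4 gives > 81000 nM, a limit and not a number, so no step linking compound 4 to compound 1, compound 2 or compound 3 can be read. The compounds shown leave open whether any of these changes, including the change in drawn configuration, shifts the half-maximal cytotoxic concentration at all: the fact that compounds 3 and 4 differ only in the configuration as drawn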